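Chalcone-triazole series: bromo on the benzyl ring

The source may report more compounds than this note shows. Statements on the series, on what has been measured and on what is new or still open speak of the compounds shown alone.

Measured compounds:
compound 1 `O=C(/C=C/c1ccc(OCc2cn(Cc3cccc(Br)c3)nn2)cc1)c1ccc(Br)cc1` 44%
compound 2 `COc1ccc(C(=O)/C=C/c2ccc(OCc3cn(Cc4ccccc4)nn3)cc2)cc1` 44%
compound 3 `O=C(/C=C/c1ccc(OCc2cn(Cc3ccccc3)nn2)cc1)c1ccc([N+](=O)[O-])cc1` "not active" (no number reported)

In a functional assay on A549 cells (Homo sapiens) for inhibition, read by MTT assay, with a stated time of 48 h, tested at 10 uM (a lower number here means less inhibition of growth, a higher number more inhibition of growth at the concentration tested), compound 1 gives 44% and compound 2 gives 44%; these two values lie within the usual scatter of each other, so no order between them is claimed. Compound 3 carries a nitro group on the ketone-side ring and, in this assay, is recorded only as "not active" (no number reported), with no single number; it therefore stands apart from compound 1 and compound 2 without a numerical position.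

Compound 4 `O=C(/C=C/c1ccc(OCc2cn(Cc3cccc(Br)c3)nn2)cc1)c1ccc([N+](=O)[O-])cc1` has not been measured. It differs from compound 3 by bromo in place of hydrogen on an aromatic carbon. Among the measured compounds shown here, no measured pair shows this change in isolation, so its size cannot be read from the numbers at hand; the only related observation is that compound 1, which has the same 3-bromobenzyl group, gives 44%. Given that compound 3 returned no number, the step is expected to be modest, if present, and more likely upward than downward, though a result again without a number remains plausible. Compound 4 is estimated at 25% in this assay, with a range from 5% to 48%.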

Compound 4, percent growth inhibition at one concentration: 28%
Compound 4: middle estimate off by 3 percentage points, on the low side; low and high end bracket the measured number.
By their numbers in this assay, from the lowest: compound 4; then compounds 1 and 2 (each within the scatter of the next).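

In this assay compound 3 stands without a number, while compound 4 gives 28%, so with the nitro group held, the change from benzyl to 3-bromobenzyl goes with a reading that can be stated as a number, though the size of that change cannot be read. Among the compounds shown here, with the 3-bromobenzyl group held, nitro in place of bromo on an aromatic carbon comes with a number 16 percentage points lower from compound 1 to compound 4 (beyond the scatter), the first numbered step, which shows that the group on that carbon matters to the reading in this one pair. No measurement at hand offers an explanation for either change.

The compounds shown contain no pair in which hydrogen and bromo on the benzyl group can both be set against a number, so it remains open how much bromo itself contributes and whether that contribution holds with groups other than nitro on the other aromatic ring. Also open, on these data alone, is how the reading in this assay would respond to an amine or a carboxylic acid in place of the nitro group, or to a longer chain in place of the benzyl group.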